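Working notes: from 2-nitrophenyl to 4-nitrophenyl

The source may hold more compounds than are shown below. What is called first, only, known or untested is meant among the compounds shown, and "the series" means these compounds.

Measured so far in a functional assay on CCRF-CEM cells (Homo sapiens) for cytotoxicity (a higher number here means that more compound is tolerated, a lower number that less compound is tolerated), for this series
- compound 1 `C/C(=N\c1nc(NC2CC2)c2ncn(C3C=CC(CO)C3)c2n1)c1ccc(O)cc1` gives 62000 nM here
- compound 2 `O=[N+]([O-])c1ccccc1/C=N/c1nc(NC2CC2)c2ncn(C3C=CC(CO)C3)c2n1` gives 13000 nM here
- compound 3 `O=C1Nc2ccc(F)cc2/C1=N\c1nc(NC2CC2)c2ncn(C3C=CC(CO)C3)c2n1` gives 56000 nM here

Compound 2 has the lowest of the three numbers, and the gaps up to compound 3 and compound 1 both lie beyond the scatter. Compound 1 and compound 3 lie within the scatter of each other.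

The next compound to be tested is compound 4 `O=[N+]([O-])c1ccc(/C=N/c2nc(NC3CC3)c3ncn(C4C=CC(CO)C4)c3n2)cc1` with the same atoms as compound 2 joined differently, as follows: 4-nitrophenyl in place of 2-nitrophenyl on a carbon with a double bond to nitrogen and so 4-nitrophenyl stands in place of 2-nitrophenyl on a carbon with a double bond to nitrogen. For the measured compounds named here, no measured pair isolates a change of this kind, so the size of the step has no direct precedent. The expectation in this assay is no step beyond the scatter, with a slight upward lean. That lean rests only on compound 2 at 13000 nM being the lowest of the three, since compound 1 at 62000 nM and compound 3 at 56000 nM both stand higher. The expected size is a 1.4-fold higher number from compound 2 to compound 4 (0.14 log units; within the scatter) on this reasoning. For compound 4 the estimated value is 18000 nM with an expected range from 7000 nM to 50000 nM in this assay.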

Compound 4, half-maximal cytotoxic concentration: 12000 nM
The estimate for compound 4 lay 1.5-fold (0.18 log units) above the measured number; low and high end bracket the measured number.
By their numbers in this assay, from the lowest: compounds 4 and 2 (each within the scatter of the next); then compounds 3 and 1 (each within the scatter of the next).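

In this assay, for the compounds shown here, 4-nitrophenyl in place of 2-nitrophenyl on a carbon with a double bond to nitrogen gives a 1.1-fold lower number from compound 2 to compound 4 (0.03 log units; within the scatter) and is the first step that isolates a change in one place. At this place, therefore, exchanging 2-nitrophenyl for 4-nitrophenyl, two groups with the same atoms and the same counts of donors and acceptors, leaves the number within the scatter, so compound 2 and compound 4 cannot be told apart in this assay. No measurement at hand bears on why the two groups read alike.

The compounds shown leave open whether this place stays as tolerant of change when the nitro group on the phenyl ring gives way to something of a different kind, such as an amine or a carboxylic acid. Also open, as far as these compounds go, is what an unsubstituted phenyl would give on the shared core, which would show whether the nitro group matters at all to the number in this assay at this place.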